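Fluoro for methoxy: from compound 2 toward compound 4

A few compounds are considered here, and "the series" means these few. Any claim that something is new, unique, unknown or untested is made for them only; others in the source may bear on it.

Compound 1 `O=C(Nc1cccc([N+](=O)[O-])c1)Nc1nc2ccc(F)cc2s1` gives 0.83 ug/mL in a functional assay on NUGC-3 cells (Homo sapiens) for antiproliferative activity, read by sulforhodamine B assay; on this read-out higher numbers stand for weaker inhibition of growth and lower numbers for stronger inhibition of growth. Compound 2 `COc1ccccc1NC(=O)Nc1nc2ccc(F)cc2s1` returns only > 10 ug/mL in this assay, a limit of the assay and not a number. Compound 3 `COc1cccc2sc(NC(=O)c3ccc(C#N)cc3)nc12`, built on a different core, also returns > 10 ug/mL in this assay, a limit. Compound 2 therefore stands at the limit of > 10 ug/mL in this assay, at which 2 of the 3 values shown sit, with no number that can be set against compound 1. Compound 4 `O=C(Nc1nc2ccc(F)cc2s1)Nc1ccccc1F` differs from compound 2 by fluoro in place of methoxy on an aromatic carbon. For the measured compounds named here, no measured step of this kind exists in the set, so the direction in this assay is open; the expected step is an at least 1.2-fold lower number from compound 2 to compound 4 (0.09 log units; that floor lies within the scatter), near or within the scatter. Compound 4 is expected at 8 ug/mL, within 2 ug/mL to 30 ug/mL, with a fair chance that only a limit is reported.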

Compound 4, concentration for 50% growth inhibition: > 10 ug/mL
Compound 4 was reported as a limit (the forecaster's own chance of this, stated with the estimate: 60%); middle value at least 1.2-fold (0.09 log units) from the limit.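

Compound 2 and compound 4 both stand at a limit of the assay, so the step between them cannot be read: the limit of > 10 ug/mL in this assay, at which 3 of the 4 values shown sit.

The compounds shown leave open whether fluoro in place of methoxy on an aromatic carbon shifts growth inhibition in either direction in this assay.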